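Fluoro on the N-aryl ring of a benzoxazinone

The source may report more compounds than this note shows. Statements on the series, on what has been measured and on what is new or still open speak of the compounds shown alone.

Compound 1 `COc1ccc(N2C(=O)COc3ccc(-c4cnc(OC)c(NS(=O)(=O)c5ccc(F)cc5)c4)cc32)cc1`: 13100 nM
Compound 2 `O=C1COc2ccc(-c3cnc4ccccc4c3)cc2N1c1ccccc1`: > 40000 nM
Compound 3 `O=C1COc2ccc(-c3cnc(Cl)c(NS(=O)(=O)c4ccc(F)cc4)c3)cc2N1C1CCCCC1`: > 40000 nM

Of the compounds shown here, three have been tested in a functional assay on HepG2 cells (Homo sapiens) for antiproliferative activity, read by MTT assay, with a stated time of 72 h; on this read-out lower numbers stand for stronger inhibition and higher numbers for weaker inhibition. Compound 1 gives 13100 nM in this assay. For compound 2 the assay reports only a limit, > 40000 nM, and not a number. For compound 3 the result is likewise a limit, > 40000 nM. Compound 2 therefore stands at the edge of what this assay can resolve, and the evidence here is the limit of > 40000 nM in this assay, at which 2 of the 3 values shown sit.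

The step considered goes from compound 2 to compound 4 `O=C1COc2ccc(-c3cnc4ccccc4c3)cc2N1c1ccc(F)cc1`. The change is fluoro in place of hydrogen on an aromatic carbon. Going by the values given here, no step between two measured compounds is available that would show how such a change plays out in this assay, so the expectation for compound 4 rests on compound 2 alone.

Since compound 2 already reaches only the limit of this assay, compound 4 is expected to behave much the same, with a step from compound 2 to compound 4 of a step that the limit leaves unreadable from compound 2 to compound 4, which is none beyond the scatter. For compound 4 the estimated value is 45000 nM, with a range from 15000 nM to 150000 nM, and most likely the assay will again report only a limit.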

Compound 4, half-maximal inhibitory concentration: 37200 nM
Compound 4: middle estimate off by 1.2-fold (0.08 log units), on the high side; measured number inside the range.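

In this assay, the change from phenyl to 4-fluorophenyl, with fluoro on an aromatic carbon para to a large group, amounts to an at least 1.0-fold lower number from compound 2 to compound 4 (0.03 log units; that floor lies within the scatter). Compound 2 is known only as a limit, > 40000 nM. Compound 4 gives an actual number, 37200 nM, so this position now has a measured anchor on the shared core. The real size of the step remains unknown, and the data show only a floor that does not go beyond the scatter: the limit of > 40000 nM in this assay, at which 2 of the 4 values shown sit.

The compounds shown leave open whether an amine or a carboxylic acid at this same place on the ring would move the value in this assay clearly away from that of compound 4. They also leave open whether fluoro in place of hydrogen at this position would have any readable effect on the core of compound 1, which already gives a number in this assay's range.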